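The source may report more compounds than this note shows. Statements on the series, on what has been measured and on what is new or still open speak of the compounds shown alone.

Measured in an ADME assay on microsomes from liver (Mus musculus) for metabolic stability, read by LC-MS, with a stated time of 30 min, tested at 1 uM; on this read-out higher numbers stand for a more stable compound and lower numbers for a less stable compound:
- Compound 1 `CC[C@@H]1CC[C@@H](C(=O)N2CCN(C(C)=O)CC2)N1C(=O)C1=C(C(C)C)N2C(=N[C@@](C)(c3ccc(Cl)cc3)[C@H]2c2ccc(Cl)cc2)S1`: 38%
- Compound 2 `CC[C@@H]1CC[C@@H](C(=O)N2CCOCC2)N1C(=O)C1=C(C(C)C)N2C(=N[C@@](C)(c3ccc(Cl)cc3)[C@H]2c2ccc(Cl)cc2)S1`: 6%

Compound 2 holds the lower of the two numbers, and the gap to compound 1 lies beyond the scatter. The next compound, compound 3 `CC[C@@H]1CC[C@@H](C(=O)N2CCN(C)[C@H](C)C2)N1C(=O)C1=C(C(C)C)N2C(=N[C@@](C)(c3ccc(Cl)cc3)[C@H]2c2ccc(Cl)cc2)S1`, changes the same amide group: 3,4-dimethylpiperazin-1-yl in place of morpholin-4-yl on a carbonyl carbon. For the measured compounds named here, only one measured step bears on this change: a number 32 percentage points lower from compound 1 to compound 2 (beyond the scatter). It is large and occurs on the same carbonyl carbon. Going by the values given here, the 3,4-dimethylpiperazin-1-yl of compound 3 resembles the 4-acetylpiperazin-1-yl of compound 1 only in part, and no measured compound carries this group. Only part of the large step is therefore expected to return in this assay. The expected change is a number 8 percentage points higher from compound 2 to compound 3 (within the scatter), a small rise that may stay within the scatter. For compound 3 the estimated value is 14%, with an expected range of 3% to 35%.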

Compound 3, percent of the compound remaining: 76%
Compound 3: the middle estimate sits 62 percentage points below what was measured; the whole stated range lies below it.
By their numbers in this assay, from the lowest: compound 2; then compound 1; then compound 3.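

In this assay, 3,4-dimethylpiperazin-1-yl on the carbonyl carbon gives a number 70 percentage points higher from compound 2 to compound 3 (beyond the scatter) when it replaces morpholin-4-yl and a number 38 percentage points higher from compound 1 to compound 3 (beyond the scatter) when it replaces 4-acetylpiperazin-1-yl. The earlier pair showed only that this place on the carbonyl carbon could separate two groups; the new result shows that 4-acetylpiperazin-1-yl does not mark the top of the range, as compound 3 stands beyond the scatter above both other compounds while the rest of the structure stays the same. Nothing shown here accounts for the size of either step.

As far as these compounds go, it remains open how 4-methylpiperazin-1-yl or unsubstituted piperazin-1-yl would compare on this carbonyl carbon. The opposite stereoisomer of 3,4-dimethylpiperazin-1-yl also remains open, so the compounds shown do not tell whether the defined stereocentre matters.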